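Replacing the cyclohexyl group of compound 3

The source may report more compounds than this note shows. Statements on the series, on what has been measured and on what is new or still open speak of the compounds shown alone.

Of the compounds shown here, three sharing one core have been measured in a physicochemical assay for lipophilicity, at pH 7.4; a higher number here means a more lipophilic compound, a lower number a more polar compound. Compound 1 `CNC(=O)c1cc(C(=O)NC2CC2)cn(Cc2ccc(OC)cc2)c1=O` gives 3, compound 2 `CNC(=O)c1cc(C(=O)NC2CC2)cn(Cc2ccc(C)cc2)c1=O` gives 3.5, and compound 3 `CNC(=O)c1cc(C(=O)NC2CC2)cn(CC2CCCCC2)c1=O` gives 4, the highest of the three. Compound 4 `CNC(=O)c1cc(C(=O)NC2CC2)cn(Cc2cccc3[nH]ccc23)c1=O` has not been measured yet. It differs from compound 3 in one place, where 1H-indol-4-yl stands in place of cyclohexyl on a saturated chain carbon bound to an aromatic nitrogen (1H-indol-4-yl in place of cyclohexyl on a saturated chain carbon bound to an aromatic nitrogen).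

Among the compounds with values here, two measured steps bear on this change, since both make a swap at that same place and both end in cyclohexyl. They are a number 0.50 log units higher from compound 2 to compound 3 (beyond the scatter) and a number 1.00 log units higher from compound 1 to compound 3 (beyond the scatter). Read in reverse, they point to a modest fall when cyclohexyl leaves and an aromatic group enters. A third step, a number 0.50 log units higher from compound 1 to compound 2 (beyond the scatter), shows that the aromatic groups also differ from one another. Within the data shown here, no measured compound carries 1H-indol-4-yl, so this reading remains uncertain.

The expected change is a number 0.70 log units lower from compound 3 to compound 4 (beyond the scatter), a modest fall in this assay. For compound 4 the estimated value is 3.3, with an expected range from 2.8 to 3.8.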

Compound 4, distribution coefficient: 2.9
The estimate for compound 4 lay 0.40 log units above the measured number; the measured number falls inside the stated range.
By their numbers in this assay, from the lowest: compounds 4 and 1 (each within the scatter of the next); then compound 2; then compound 3.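

Placing 1H-indol-4-yl on the saturated chain carbon bound to an aromatic nitrogen brings a large fall (a number 1.10 log units lower from compound 3 to compound 4 (beyond the scatter)), even though it has 9 heavy atoms against 6 in cyclohexyl, so in this set more heavy atoms at this place do not go with a higher number. The fall also goes beyond what separates the methylphenyl group from the indole (a number 0.60 log units lower from compound 2 to compound 4 (beyond the scatter)), while the methoxyphenyl group and the indole cannot be told apart (a number 0.10 log units lower from compound 1 to compound 4 (within the scatter)). No measurement here explains these steps.

Still open, going by these compounds, is how much of the fall belongs to the indole's hydrogen-bond donor, which a comparison with a naphthyl group, all carbon, would help to show. Also open, on these data alone, is whether 1H-indol-5-yl would give a similar number.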